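Methyl for isopropyl on a second ring of the shared core

This account rests on a few compounds, and the source may have more. Where it says the series, first, only, none or still open, it means among the compounds named here.

Of the compounds shown here, three have been measured in a functional assay on B16-F10 cells (Mus musculus) for inhibition, read by MTT assay, with a stated time of 72 h; a higher number here means a weaker inhibitor, a lower number a stronger inhibitor. Compound 1, `COc1ccccc1Nc1nc(SCc2cn(CC(=O)NC(=O)Nc3ccccn3)nn2)nc(-c2ccc(C(C)C)cc2)c1C#N`, gives 34600 nM. Compound 2, `COc1ccccc1Nc1nc(SCc2cn(CC(=O)NC(=O)Nc3ccccn3)nn2)nc(-c2ccc(C)cc2)c1C#N`, gives 8580 nM. Compound 3, `CC(C)c1ccc(Nc2nc(SCc3cn(CC(=O)NC(=O)Nc4ccccn4)nn3)nc(-c3ccc(Cl)cc3)c2C#N)cc1`, gives 1590 nM, the lowest of the three numbers.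

The step of a 4.0-fold lower number from compound 1 to compound 2 (0.61 log units; beyond the scatter) corresponds to methyl in place of isopropyl on an aromatic carbon. The cores of compound 1 and compound 3 differ in more than one place, and the difference between them is not broken down here.

Compound 4, `Cc1ccc(Nc2nc(SCc3cn(CC(=O)NC(=O)Nc4ccccn4)nn3)nc(-c3ccc(Cl)cc3)c2C#N)cc1`, has not yet been measured. It differs from compound 3 by methyl in place of isopropyl on an aromatic carbon. This is the same change as that from compound 1 to compound 2, though read one bond further out it sits on the (4-isopropylphenyl)amino part rather than on the 4-isopropylphenyl ring, so the surroundings are not identical.

Going by the values given here, the only measured precedent is a 4.0-fold lower number from compound 1 to compound 2 (0.61 log units; beyond the scatter), which went beyond the usual scatter. Because the precedent a 4.0-fold lower number from compound 1 to compound 2 (0.61 log units; beyond the scatter) sits on a ring other than the one changed here, a somewhat smaller step is expected from compound 3 to compound 4, namely a 2.4-fold lower number from compound 3 to compound 4 (0.39 log units; beyond the scatter). On that basis compound 4 is expected to give about 650 nM in this assay, with the estimate running from 250 nM to 2000 nM.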

Compound 4, half-maximal inhibitory concentration: 1320 nM
Compound 4: middle estimate off by 2.0-fold (0.31 log units), on the low side; the range from low to high includes it.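

In this assay, putting methyl in place of isopropyl on the anilino-side ring gives a 1.2-fold lower number from compound 3 to compound 4 (0.08 log units; within the scatter), so on this core the change leaves the two compounds indistinguishable. Carried from one core to another in this series, the change therefore does not keep a fixed size, and a step beyond the scatter on one core did not reappear on the other: the same change on two cores in this assay, a 4.0-fold lower number (0.61 log units; beyond the scatter) from compound 1 to compound 2 and a 1.2-fold lower number (0.08 log units; within the scatter) from compound 3 to compound 4, 3.3-fold (0.52 log units) apart, beyond the scatter of two such steps. This does not show which of the several differences between the core of compound 1 and the core of compound 3 sets the two steps apart, and two pairs are too few to give a rule for any other core in the series.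

The compounds shown leave open what an ethyl group, a tert-butyl group or a carboxylic acid would give at the same place on an aromatic carbon, and whether the step would then follow the pattern of the first core or the second. They also leave open whether the gap between the two steps would hold in any read-out other than this assay.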